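Butyl for Isopropyl: What Compound 4 Might Give

The compounds below may be only part of what the source reports. "The series", "measured", "known", "first", "only" and "open" are said of these compounds alone.

Compound 1 `CCCNC(=O)c1cc(-n2cc(CCC(C)C)nn2)ccc1O`: in a functional assay on RAW264.7 cells (Mus musculus) for inhibition, read by Griess assay, with a stated time of 20 h (on this read-out higher numbers stand for weaker inhibition and lower numbers for stronger inhibition), compound 1 gives > 20000 nM, a limit of the assay.
Compound 2 `CCCCCCc1cn(-c2ccc(O)c(C(=O)NCCC)c2)nn1`: in this assay compound 2 gives 19700 nM.
Compound 3 `CCCNC(=O)c1ccc(-n2cc(CCC(C)C)nn2)cc1O`: in this assay compound 3 gives > 20000 nM, a limit of the assay.

Compound 1 and compound 3 share the same atoms joined differently; the difference between the two cores is not broken down here. The change butyl in place of isopropyl on a saturated chain carbon, two bonds along the chain from an aromatic carbon produced an at least 1.0-fold lower number from compound 1 to compound 2 (0.00 log units; that floor lies within the scatter), a step that cannot be read as a change, because the limit of > 20000 nM in this assay, at which 2 of the 3 values shown sit, marks where compound 1 sits. Compound 4 `CCCCCCc1cn(-c2ccc(C(=O)NCCC)c(O)c2)nn1` carries the same change on the core of compound 3, (butyl in place of isopropyl on a saturated chain carbon, two bonds along the chain from an aromatic carbon). On the evidence of an at least 1.0-fold lower number from compound 1 to compound 2 (0.00 log units; that floor lies within the scatter), the step of a number no higher from compound 3 to compound 4 (the limit leaves the size open) is expected to be of similar size. Compound 4 is thus estimated at 20000 nM, with a range from 12000 nM to 40000 nM.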

Compound 4, half-maximal inhibitory concentration: > 20000 nM
Compound 4: a limit, no number; the forecaster's own chance of this, stated with the estimate: 60%; the middle value sits exactly at the limit.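

No step can be read from compound 3 to compound 4, because both values are limits of the assay: the limit of > 20000 nM in this assay, at which 3 of the 4 values shown sit.

The compounds shown leave open how strongly compound 1, compound 3 and compound 4 inhibit, and whether the two cores differ at all.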